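Series notes: benzodiazepine-type esters and T-type channel inhibition

The source may hold more compounds than are shown below. What is called first, only, known or untested is meant among the compounds shown, and "the series" means these compounds.

Measured so far: compound 1 `COC(=O)CC1c2ccccc2N=C(N2CCOCC2)N1C1CCCCC1` gives 12.2% in a functional assay on cells (Oocyte) for inhibition of Voltage-dependent T-type calcium channel subunit alpha-1H (Homo sapiens), tested at 100 uM; on this read-out higher numbers stand for more inhibition at the one concentration tested (going by the name of the read-out) and lower numbers for less inhibition; compound 2 `COC(=O)CC1c2ccccc2N=C(N2CCN(C)CC2)N1C1CCCCC1` gives 3%; compound 3 `COC(=O)CC1c2ccccc2N=C(N2CCOCC2)N1C(C)C` gives about 0%.

All three share one core; the two changes made to it are 4-methylpiperazin-1-yl in place of morpholin-4-yl on a carbon with a double bond to nitrogen and (isopropyl in place of cyclohexyl on an amine nitrogen in a ring). The first of these gave a number 9.2 percentage points lower from compound 1 to compound 2 (within the scatter), the second a number 12.2 percentage points lower from compound 1 to compound 3 (beyond the scatter). Compound 2 and compound 3 lie within the scatter of each other, so no order between them is claimed.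

Compound 4 `COC(=O)CC1c2ccccc2N=C(N2CCN(C)CC2)N1C(C)C` is not yet measured. It relates to compound 3 by 4-methylpiperazin-1-yl in place of morpholin-4-yl on a carbon with a double bond to nitrogen, the same kind of change as that from compound 1 to compound 2, but the surroundings differ: in compound 1 the carbon carrying the change sits next to the ring atom that bears a cyclohexyl group, whereas in compound 3 it sits next to the ring atom that bears an isopropyl group.

Compound 3 already shows a very low value, so the step is expected to be small, a number 1 percentage points higher from compound 3 to compound 4 (within the scatter), because compound 3 gives about 0% and cannot fall far below it. The estimate for compound 4 in this assay is 1%, with a range from -6% to 8%.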

Compound 4, a percentage reported as inhibition, at one concentration (the size of the read-out at that concentration, not a potency): about 0%
Compound 4: the middle estimate sits 1 percentage points above what was measured; the measured number falls inside the stated range.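

In this assay, 4-methylpiperazin-1-yl in place of morpholin-4-yl gives no change at the digits printed from compound 3 to compound 4 (within the scatter), and this step does not differ from the one seen with cyclohexyl on the ring nitrogen: the same change on two cores in this assay, a number 9.2 percentage points lower (within the scatter) from compound 1 to compound 2 and no change at the digits printed (within the scatter) from compound 3 to compound 4, 9.2 percentage points apart, within the scatter of two such steps. Isopropyl in place of cyclohexyl gives a number 3 percentage points lower from compound 2 to compound 4 (within the scatter), and this step likewise does not differ from the one seen with morpholin-4-yl: the same change on two cores in this assay, a number 12.2 percentage points lower (beyond the scatter) from compound 1 to compound 3 and a number 3 percentage points lower (within the scatter) from compound 2 to compound 4, 9.2 percentage points apart, within the scatter of two such steps. Neither comparison shows that a step keeps its size from one core to the other, as compound 3 and compound 4 both lie at the very bottom of the read-out, where little room for a further fall remains.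

Still open, from the compounds shown here alone, is whether a larger group than cyclohexyl on the ring nitrogen, such as benzyl, would give more inhibition than compound 1 does. Equally open, going by these compounds, is how a carboxylic acid in place of the methyl ester, or an open-chain amine such as dimethylamino in place of the ring amines, would read in this assay.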